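Removing the benzamido group on a shared cyclopentenone core

A few compounds are considered here, and "the series" means these few. Any claim that something is new, unique, unknown or untested is made for them only; others in the source may bear on it.

Compound 1 `COc1ccc(C2=C(c3cc(OC)c(OC)c(OC)c3)C(=O)C(OC(C)=O)C2)cc1Cl` and compound 3 `COc1ccc(C2=C(c3cc(OC)c(OC)c(OC)c3)C(=O)C(OC(C)=O)C2)cc1OC(C)C` share one core and differ at a single aromatic carbon. In an ADME assay on HEp-2 cells (Homo sapiens) for cytotoxicity, read by MTT assay, with a stated time of 72 h (on this read-out lower numbers stand for stronger inhibition and higher numbers for weaker inhibition), compound 1 sits at a limit of the assay, < 1 ug/mL. Compound 3 also sits at a limit in this assay, > 100 ug/mL. The step of an at least 100-fold higher number from compound 1 to compound 3 (2.00 log units; beyond the scatter) shows that a change at this one position can move the number a long way. Compound 2 `COc1ccc(C2=C(c3cc(OC)c(OC)c(OC)c3)C(=O)C(O)C2)cc1NC(=O)c1ccccc1` carries a benzamido group at the same position and a hydroxyl instead of the acetate. In this assay compound 2 sits at a limit, > 100 ug/mL. It therefore stands with the weaker pair, at the limit of > 100 ug/mL in this assay, at which 2 of the 3 values shown sit, and only compound 1 lies at the limit of < 1 ug/mL in this assay, at which 1 of the 3 values shown sits.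

Compound 4 `COc1ccc(C2=C(c3cc(OC)c(OC)c(OC)c3)C(=O)C(O)C2)cc1` differs from compound 2 by hydrogen in place of benzamido on an aromatic carbon. For the measured compounds named here, the only measured step, from compound 1 to compound 3, exchanges one group for another at this carbon and is at least large; no step removes a group there altogether, and compound 2 is a limit rather than a number. He therefore expects a step of an at least 5.0-fold lower number from compound 2 to compound 4 (0.69 log units; beyond the scatter) toward a lower number, with wide uncertainty. Compound 4 is estimated at 20 ug/mL, within 2 ug/mL to 100 ug/mL.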

Compound 4, half-maximal inhibitory concentration: < 1 ug/mL
Compound 4 gave a limit, no number (the forecaster's own chance of this, stated with the estimate: 40%); middle value at least 20-fold (1.30 log units) from the limit.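

For the compounds shown here, the step of an at least 100-fold lower number from compound 2 to compound 4 (2.00 log units; beyond the scatter) in this assay is the first at this aromatic carbon that removes a group instead of exchanging one, and it shows that the benzamido group is not needed for the low end of the read-out. The earlier step of an at least 100-fold higher number from compound 1 to compound 3 (2.00 log units; beyond the scatter) was seen with the acetate on the shared core, whereas the new one is seen with the hydroxyl, so a large swing at this carbon is not confined to compounds carrying the acetate. Compound 2 and compound 4 each stand at a limit of the assay and not at a number, so the step gives only a minimum for the change and its true size cannot be read: the limit of < 1 ug/mL in this assay, at which 2 of the 4 values shown sit.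

Going by these compounds, what an amine or a short ethoxy chain at this aromatic carbon would give remains open, and so does where, between hydrogen and benzamido, the read-out turns from one limit to the other. Also open, on these data alone, is what exchanging the acetate for the hydroxyl does on its own while the group at this carbon stays the same.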